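The source may hold more compounds than are shown below. What is called first, only, known or untested is meant among the compounds shown, and "the series" means these compounds.

compound 1 `CC(=O)SCCC(CCCCC(=O)O)SC(C)=O`: 6.04%
compound 2 `O=C(CCCCC(S)CCS)Nc1ccccc1Cl`: 18.2%

Among the measured compounds shown here, in a functional assay on NCI-H460 cells (Homo sapiens) for inhibition, read by MTT assay, with a stated time of 24 h, tested at 10 ug/mL (on this read-out higher numbers stand for more inhibition of growth at the one concentration tested and lower numbers for less inhibition of growth), compound 1 gives 6.04% as the lower of the two known numbers, and the gap up to compound 2 lies beyond the usual scatter. The next candidate is compound 3 `CC(=O)SCCC(CCCCC(=O)Nc1cccc(Cl)c1)SC(C)=O`, which keeps the core of compound 1 and changes one place: (3-chlorophenyl)amino in place of hydroxy on a carbonyl carbon puts (3-chlorophenyl)amino in place of hydroxy on a carbonyl carbon. For the measured compounds named here, no measured pair shows this change on its own, so the evidence is thin. Going by the values given here, the one guide is compound 2, which also holds a chlorine-bearing aromatic ring and gives 18.2% in the same test. A moderate rise is therefore expected in this assay, and the estimated step is a number 12 percentage points higher from compound 1 to compound 3 (beyond the scatter) in this direction. Compound 3 is expected at 18% with an estimated range from 5% to 40% in this test.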

Compound 3, percent growth inhibition at one concentration: 2.09%
Estimate against measurement, compound 3: 15.9 percentage points above; the whole stated range lies above it.
By their numbers in this assay, from the lowest: compounds 3 and 1 (each within the scatter of the next); then compound 2.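

In this assay, among the compounds shown here, putting (3-chlorophenyl)amino in place of hydroxy on a carbonyl carbon gives a number 4 percentage points lower from compound 1 to compound 3 (within the scatter) and is the first direct look at this change at this position. The swap replaces 1 heavy atom with 8 and adds a six-membered aromatic ring of carbon only, yet this single-concentration test does not tell compound 1 and compound 3 apart. No supporting measurement is available to explain this result.

The compounds shown leave open whether a plain phenylamino group, without the chlorine, or a simple amine such as methylamino on the same carbonyl carbon would read any differently. From the compounds shown here alone, compound 2 differs from compound 3 in more than one place, so the role of the acetyl groups on sulfur also remains open.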